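A few compounds are considered here, and "the series" means these few. Any claim that something is new, unique, unknown or untested is made for them only; others in the source may bear on it.

Compound 1 `COc1cc2c(Oc3ccc(NC(=O)NC4CCCCC4)cc3)ccnc2cc1OCCCCCCC(=O)NO`: 850 nM
Compound 2 `COc1cc2c(Oc3ccc(NC(=O)N/N=C/c4ccccc4)cc3)ccnc2cc1OCCCCCCC(=O)NO`: 3700 nM

In a functional assay on A549 cells (Homo sapiens) for antiproliferative activity, read by MTT assay (on this read-out lower numbers stand for stronger inhibition and higher numbers for weaker inhibition), compound 2, at 3700 nM, holds the higher of the two numbers, so it is the weaker inhibitor of the pair. Compound 3 `COc1cc2c(Oc3ccc(NC(=O)NNC(=O)c4cccc(C)c4)cc3)ccnc2cc1OCCCCCCC(=O)NO` keeps the shared core and replaces the group on the amide-type nitrogen: a group of 10 heavy atoms (8 carbon, 1 nitrogen, 1 oxygen; one six-membered aromatic ring of carbon only) in place of a group of 8 heavy atoms (7 carbon, 1 nitrogen; one six-membered aromatic ring of carbon only), on an amide-type nitrogen. The incoming ((3-methylphenyl)carbonyl)amino group retains a six-membered aromatic ring of carbon only. Just one measured step bears on this change, since it was made at the same nitrogen: a 4.4-fold higher number from compound 1 to compound 2 (0.64 log units; beyond the scatter). That step was modest, and a single step gives no firm direction for a different replacement. A change of similar or smaller size is therefore expected, leaning slightly towards a lower number. The expected step is a 1.5-fold lower number from compound 2 to compound 3 (0.17 log units; within the scatter). Compound 3 is estimated at 2500 nM, with an expected range of 700 nM to 8000 nM.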

Compound 3, half-maximal inhibitory concentration: 8190 nM
The estimate for compound 3 lay 3.3-fold (0.52 log units) below the measured number; the measured number lies above the stated range.
By their numbers in this assay, from the lowest: compound 1; then compound 2; then compound 3.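

In this assay, putting ((3-methylphenyl)carbonyl)amino on the amide-type nitrogen gave a further rise in the number (a 2.2-fold higher number from compound 2 to compound 3 (0.35 log units; beyond the scatter)), a step beyond the usual scatter. This shows that the second aromatic replacement did not recover what was lost with the first, and that this nitrogen remains sensitive to the group it carries. Against cyclohexyl, the gap has widened (a 9.6-fold higher number from compound 1 to compound 3 (0.98 log units; beyond the scatter)), so among these three compounds, the saturated ring on this nitrogen gives the lowest number, and the two groups carrying a benzene ring both give higher ones.

Going by these compounds, whether a smaller group such as ethyl, or a cyclopentyl ring, would give a lower number than compound 1 remains open. Nothing available here explains the order of the three numbers.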